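Furan-2-yl for pyridin-3-yl: expected inhibition of compound 4

The compounds below may be only part of what the source reports. "The series", "measured", "known", "first", "only" and "open" are said of these compounds alone.

Of the compounds shown here, three have been tested in an assay on CHO cells for displacement of a labelled ligand from adenosine receptor A1 (Homo sapiens), read by scintillation counting, tested at 10 uM; a higher number here means more inhibition at the concentration tested (going by the name of the read-out), a lower number less inhibition. Compound 1 `Cc1c(Br)sc(N)c1C(=O)c1ccc(Cl)cc1` gives 1%. Compound 2 `CC(C)(C)Cc1c(-c2cccnc2)sc(N)c1C(=O)c1ccc(Cl)cc1` gives 1% in this assay, and compound 3 `COc1ccc(-c2sc(N)c(C(=O)c3cccc(Cl)c3)c2CC(C)(C)C)cc1` gives 1%. Compound 2 therefore stands level with compound 1 and with compound 3 at the digits reported; the gaps among the three lie within the scatter of repeated measurements, so no order among them can be read from these numbers.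

Compound 4 `CC(C)(C)Cc1c(-c2ccco2)sc(N)c1C(=O)c1ccc(Cl)cc1` has not yet been measured in this assay. It differs from compound 2 in one place: furan-2-yl in place of pyridin-3-yl on an aromatic carbon. Among the measured compounds shown here, no pair of measured compounds differing in a single place is available, so the size of such a change cannot be taken from the series itself. Given that every measured compound sits at the same low level, no step beyond the scatter is expected in this assay, in either direction. The estimate for compound 4 is 2%, with a range from -8% to 12%. The step this estimate means, a number 1 percentage points higher from compound 2 to compound 4 (within the scatter), is expected to lie within the scatter.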

Compound 4, a percentage reported as inhibition, at one concentration (the size of the read-out at that concentration, not a potency): 1%
The estimate for compound 4 lay 1 percentage points above the measured number; low and high end bracket the measured number.
By their numbers in this assay, from the lowest: compounds 1, 2, 3 and 4 (each within the scatter of the next).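

Among the compounds shown here, compounds 2 and 4 form the first pair that differs in one place: in this assay, furan-2-yl in place of pyridin-3-yl on the aromatic carbon next to the ring sulfur gives no change at the digits printed from compound 2 to compound 4 (within the scatter). At this position, then, a five-membered aromatic ring with an oxygen and a six-membered aromatic ring with a nitrogen cannot be told apart in this read-out, though with both compounds at the low level of the whole series, the pair does not show that the two groups are equivalent. No measurement is at hand that would explain the result.

On these data alone, whether any group on this carbon lifts inhibition above this level stays open, for instance a primary amine or a carboxylic acid. The same holds for the neighbouring neopentyl group, where a shorter or longer chain could be compared.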